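From a Carboxy Aryl Ether to a Fluorophenyl Ether

A few compounds are considered here, and "the series" means these few. Any claim that something is new, unique, unknown or untested is made for them only; others in the source may bear on it.

Three related compounds have been measured in a functional assay (aorta) with Oryctolagus cuniculus as the target (a lower number here means tighter binding, a higher number weaker binding), so far. Compound 1 (`COc1cc(C(C)=O)ccc1OCCCN1CCC(=C(c2ccc(F)cc2)c2ccc(F)cc2)CC1`) gives 3.98 nM and compound 2 (`COc1cc(C(C)=O)ccc1OCCCN1CCC(C(C(N)=O)(c2ccc(F)cc2)c2ccc(F)cc2)CC1`) gives 25.1 nM in this test. Compound 3 (`COc1cc(C(=O)O)ccc1OCCCN1CCC(C(c2ccc(F)cc2)c2ccc(F)cc2)CC1`) gives 79.4 nM and so has the highest of the three numbers, with its gaps to both of the others lying beyond the scatter.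

Compound 4 (`Fc1ccc(OCCCN2CCC(C(c3ccc(F)cc3)c3ccc(F)cc3)CC2)cc1`) differs from compound 3 in one place, with 4-fluorophenyl in place of 4-carboxy-2-methoxyphenyl on an oxygen on a saturated carbon. Among the measured compounds shown here, no measured pair isolates this change, so any expectation rests on indirect evidence. Neither compound 1 (3.98 nM) nor compound 2 (25.1 nM) carries the carboxy group, and both show lower numbers than compound 3 (79.4 nM). Each of them also differs from compound 3 elsewhere, and neither carries the 4-fluorophenyl group, so this evidence is loose. The expected move is toward a lower number (a 4.0-fold lower number from compound 3 to compound 4 (0.60 log units; beyond the scatter)) and is likely, though not certain, to exceed the scatter. In this assay the estimate for compound 4 is 20 nM with an expected range of 5 nM to 80 nM around it.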

Compound 4, dissociation constant: 1.26 nM
The estimate for compound 4 lay 16-fold (1.20 log units) above the measured number; measured number outside the range, below it.
By their numbers in this assay, from the lowest: compound 4; then compound 1; then compound 2; then compound 3.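

In this assay, replacing 4-carboxy-2-methoxyphenyl with 4-fluorophenyl on an oxygen on a saturated carbon gives a 63-fold lower number from compound 3 to compound 4 (1.80 log units; beyond the scatter), a large step and the first among these compounds that isolates a change in one place. It shows that this position alone can move the number strongly, something compounds 1 and 2 could not show, since each differs from compound 3 elsewhere as well. It also shows that the very low value of compound 4, 1.26 nM, is reached with a smaller group of 7 heavy atoms, and with 0 hydrogen-bond donors and 0 hydrogen-bond acceptors on the entering group. Nothing measured here bears on why the step is so large.

Among the compounds shown here, the single step removes the carboxylic acid and the methoxy group and brings in the fluorine all at once, so the share of each in the change remains unresolved. On these data alone, how a plain phenyl or a 4-methoxyphenyl on the same oxygen would read in this assay stays open, as does whether 4-fluorophenyl would have a similar effect on the cores of compound 1 and compound 2.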